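The compounds below may be only part of what the source reports. "The series", "measured", "known", "first", "only" and "open" are said of these compounds alone.

Two measured compounds and one unmeasured compound share a common core. Compound 1 `Cc1cc(C=C(C#N)C#N)c(C)n1-c1cccc(-c2nnn[nH]2)c1` and compound 2 `Cc1cc(/C=C2\SC(=S)N(c3cccc(O)c3)C2=O)c(C)n1-c1cccc(-c2nnn[nH]2)c1` differ in the group attached to that core, and compound 3 `Cc1cc(/C=C2\SC(=S)N(c3ccc(Br)cc3)C2=O)c(C)n1-c1cccc(-c2nnn[nH]2)c1` is the one still to be tested.

In an ADME assay on MT2 cells (Homo sapiens) for cytotoxicity, read by XTT assay, with a stated time of 4 days (a higher number here means that more compound is tolerated, a lower number that less compound is tolerated), compound 1 gives only a limit, > 400000 nM, and no number. This sits at the limit of > 400000 nM in this assay, at which 1 of the 2 values shown sits, so the measurement stops there. In this assay, among the compounds with values here, compound 2 gives 35600 nM, which is the only actual number in the set. The entry for compound 1 is a limit and not a number, so no ranked order between compound 2 and compound 1 can be stated.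

Compound 3 differs from compound 2 by a single exchange: 4-bromophenyl in place of 3-hydroxyphenyl on an amide-type nitrogen in a ring. Within the data shown here, no measured pair of compounds separates at this position alone, so the size of this change cannot be read from the data. Compound 3 is therefore expected to land near 25000 nM in this assay, with a plausible range from 8000 nM to 80000 nM. The expected step of a 1.4-fold lower number from compound 2 to compound 3 (0.15 log units; within the scatter) is estimated to stay within the usual scatter of repeated measurements, or at most slightly beyond it, toward less compound tolerated.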

Compound 3, half-maximal cytotoxic concentration: 46800 nM
Estimate against measurement, compound 3: 1.9-fold (0.27 log units) below; the range from low to high includes it.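

Within the data shown here, the first pair here that differs in one place shows, in this assay, a 1.3-fold higher number from compound 2 to compound 3 (0.12 log units; within the scatter). On the amide-type nitrogen in a ring, 3-hydroxyphenyl and 4-bromophenyl therefore cannot be told apart by this read-out, even though the exchange removes the hydroxyl oxygen, with the hydrogen-bond donor and acceptor counted on it, and brings in a bromine. Nothing measured here bears on why the two groups give values this close.

Going by these compounds, whether a group of a different kind on that nitrogen, such as a carboxylic acid, an amine or a longer chain, would move the value beyond the usual scatter remains open, since the two aromatic rings compared here span only a narrow part of what could sit at this position. On these data alone, compound 1 gives > 400000 nM in this assay, which is a limit and not a number, so its steps to the other compounds cannot be read, and the effect of replacing the whole ring-bearing group on the shared core stays unknown.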